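Swapping the ethylphenyl arm for an iodo-methoxyphenyl arm

This account rests on a few compounds, and the source may have more. Where it says the series, first, only, none or still open, it means among the compounds named here.

Three compounds have been measured in a functional assay on PC-9 cells (Homo sapiens) for inhibition, read by MTT assay, with a stated time of 48 h, tested at 10 uM; a lower number here means less inhibition, a higher number more inhibition at the concentration tested (going by the name of the read-out):
Compound 1 `CCc1ccc(Nc2cc(NC(=O)Nc3cc(OC)cc(OC)c3)ncn2)cc1`: compound 1 gives 78%.
Compound 2 `COc1cc(NC(=O)Nc2cc(Nc3cc(F)ccc3OC)ncn2)cc(OC)c1`: compound 2 gives 59.5%.
Compound 3 `CCc1cccc(Nc2cc(NC(=O)Nc3cc(OC)cc(OC)c3)ncn2)c1`: compound 3 gives 82.1%.

Compound 3 holds the highest number of the three, though its gap to compound 1, a number 4.1 percentage points higher from compound 1 to compound 3 (within the scatter), lies within the scatter, so the two cannot be ordered. Only compound 2 stands clearly apart: a number 22.6 percentage points higher from compound 2 to compound 3 (beyond the scatter), and likewise a number 18.5 percentage points lower from compound 1 to compound 2 (beyond the scatter).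

Compound 4 `COc1cc(NC(=O)Nc2cc(Nc3cc(I)ccc3OC)ncn2)cc(OC)c1` is not yet measured. It differs from compound 3 in one place: 5-iodo-2-methoxyphenyl in place of 3-ethylphenyl on a nitrogen on an aromatic ring.

Within the data shown here, the step that bears on this change is the one between compound 2 and compound 3, since compound 2 also carries a 2-methoxyphenyl group with a halogen at its 5-position, and a number 22.6 percentage points higher from compound 2 to compound 3 (beyond the scatter) was a modest drop in the other direction. Among the measured compounds shown here, whether iodine behaves as fluorine does here is unknown; no compound tests that. The expectation for compound 4 is therefore a modest drop from compound 3, a number 19.1 percentage points lower from compound 3 to compound 4 (beyond the scatter), landing near compound 2. Compound 4 is estimated at 63%, with a range from 45% to 80%.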

Compound 4, a percentage reported as inhibition, at one concentration (the size of the read-out at that concentration, not a potency): 91%
Estimate against measurement, compound 4: 28 percentage points below; measured number above the stated range.
By their numbers in this assay, from the lowest: compound 2; then compounds 1, 3 and 4 (each within the scatter of the next, the first and the last beyond it).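

Iodo in place of fluoro on an aromatic carbon is the only change here confined to the halogen of the arm on the nitrogen, and it gives a number 31.5 percentage points higher from compound 2 to compound 4 (beyond the scatter) in this assay. The low number of compound 2 therefore cannot be assigned to the methoxyphenyl arm as such, since the 5-iodo-2-methoxyphenyl arm cannot be ordered against the 3-ethylphenyl arm, with a number 8.9 percentage points higher from compound 3 to compound 4 (within the scatter), and it clearly exceeds the 4-ethylphenyl arm, with a number 13 percentage points higher from compound 1 to compound 4 (beyond the scatter). At this place on the nitrogen, the swap from an ethylphenyl to a methoxyphenyl arm does not by itself fix the outcome, and the halogen carried by that arm makes a large difference. No evidence is available to explain this difference.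

Going by these compounds, whether chloro or bromo at the same place would give a number nearer that of compound 2 or that of compound 4 remains open. Also open, on these data alone, is what an amine or a carboxylic acid in place of the iodo would do, and these single-concentration readings give no potency for any of the compounds.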